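The source may hold more compounds than are shown below. What is called first, only, known or untested is meant among the compounds shown, and "the series" means these compounds.

Of the compounds shown here, three have been measured in a functional assay on Cortical neurone cells (Mus musculus, strain C57BL/6), read by FLIPR and calcium flux, with a stated time of 8 min; a higher number here means a weaker inhibitor, a lower number a stronger inhibitor. Compound 1 `Cc1ccc(Cc2nc3[nH]c(-c4ccc(Cl)cc4)cc(=O)n3n2)cc1` gives 5440 nM. Compound 2 `Cc1ccc(Cc2cc(=O)n3nc(Cc4ccc(Cl)cc4)nc3[nH]2)cc1` gives 3020 nM, and compound 3 `O=c1cc(-c2ccccc2)[nH]c2nc(Cc3ccc(F)cc3)nn12` gives 2520 nM. Compound 2 holds the second highest of the three numbers: its nearest neighbour is compound 3, whose number is lower by an amount within the scatter, and its furthest is compound 1, whose number is higher by an amount that also stays within the scatter. The three values cannot be placed in a reliable order.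

Compound 4 `O=c1cc(Cc2ccccc2)[nH]c2nc(Cc3ccc(Cl)cc3)nn12` has not yet been measured. Against compound 2 it shows this difference: hydrogen in place of methyl on an aromatic carbon. Among the compounds with values here, no pair of measured compounds differing in a single place is available, so a step of this kind has no direct precedent among the numbers known so far. The change is small in what it counts, and the expected step is a 1.0-fold lower number from compound 2 to compound 4 (0.00 log units; within the scatter), with no direction beyond the scatter. Compound 4 is therefore estimated to give about 3000 nM in this assay, within a range from 1400 nM to 7000 nM.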

Compound 4, half-maximal inhibitory concentration: 4280 nM
For compound 4 the middle estimate is 1.4-fold (0.15 log units) below the measured one; the range from low to high includes it.
By their numbers in this assay, from the lowest: compounds 3, 2, 4 and 1 (each within the scatter of the next, the first and the last beyond it).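

In this assay, within the data shown here, hydrogen in place of methyl on an aromatic carbon gives a 1.4-fold higher number from compound 2 to compound 4 (0.15 log units; within the scatter), the first step between two compounds that differ in only one place. At this position, para to a large group, the 4-methylbenzyl and benzyl forms therefore cannot be told apart, so the methyl is not shown to matter for the measured number. No supporting measurement bears on this step, and no explanation of it can be offered.

From the compounds shown here alone, whether a different group on this aromatic carbon, such as an amine, a carboxylic acid or a longer chain, would carry the number beyond the scatter remains open. This single pair also leaves open whether the same change would give a similar step in compounds with other groups elsewhere on the shared core.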